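A few compounds are considered here, and "the series" means these few. Any claim that something is new, unique, unknown or untested is made for them only; others in the source may bear on it.

Measured so far:
Compound 1, `Cc1ccc(S(=O)(=O)Nc2ccc(-c3nc4ccccc4o3)cc2)cc1`: in an assay on cells for inhibition of HSP60/HSP10 (Homo sapiens), with a stated time of 60 min (a higher number here means a weaker inhibitor, a lower number a stronger inhibitor), compound 1 gives > 100000 nM.
Compound 2, `O=S(=O)(Nc1ccc(-c2nc3ccccc3o2)cc1)c1cccc(Cl)c1`: in this assay compound 2 gives 54000 nM.

The value for compound 1 is a limit of the assay and not a number; it sits at the limit of > 100000 nM in this assay, at which 1 of the 2 values shown sits. Compound 1 thus stands at the weak edge of the series, with no measured number of its own. Within the data shown here, the single measured step, an at least 1.8-fold lower number from compound 1 to compound 2 (0.26 log units; that floor lies within the scatter), brings the number below the limit, but its floor lies within the usual scatter, so it shows no change beyond scatter on exchanging the group on the sulfonyl sulfur.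

Compound 3, `O=S(=O)(Nc1ccc(-c2nc3ccccc3o2)cc1)c1ccc(C(F)(F)F)cc1`, differs from compound 1 by trifluoromethyl in place of methyl on an aromatic carbon. The step from compound 1 to compound 2 is the only measured one bearing on this change, as it also alters the substituent on that ring, and it was small. The expected step is therefore an at least 1.2-fold lower number from compound 1 to compound 3 (0.09 log units; that floor lies within the scatter), little beyond scatter, with a fair chance that only a limit is reported. Compound 3 is estimated at 80000 nM, within 30000 nM to 250000 nM.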

Compound 3, half-maximal inhibitory concentration: 50000 nM
Compound 3: middle estimate off by 1.6-fold (0.20 log units), on the high side, within the range that was stated.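

With trifluoromethyl in place of methyl on the aromatic carbon para to a large group, the series shows an at least 2.0-fold lower number from compound 1 to compound 3 (0.30 log units; that floor lies within the scatter) and so a measured number at this position, though no change beyond scatter. Unlike the exchange of the whole aryl group in compound 2, this change keeps the ring and alters only the group on it. The value of compound 1 is a limit and not a number: the limit of > 100000 nM in this assay, at which 1 of the 3 values shown sits.

From the compounds shown here alone, the true size of the step from methyl to trifluoromethyl stays open while compound 1 has no number of its own. Also open, going by these compounds, is how an amine, a carboxylic acid or a longer chain at this position would read in this assay and whether any group here moves the number beyond scatter from that of compound 3.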